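The source may report more compounds than this note shows. Statements on the series, on what has been measured and on what is new or still open speak of the compounds shown alone.

Compound 1 `Cc1ccc(/N=N/N(C)C(=O)CCc2ccc(O)cc2)cc1` is the only one of the three measured compounds for which a physicochemical assay for pharmacokinetics, read by HPLC, in phosphate buffer, at pH 7.4 (a lower number here means that the compound disappears faster, a higher number that the compound lasts longer), reports a number: compound 1 gives 101 h. Compound 2 `CN(/N=N/c1ccc(C#N)cc1)C(=O)NCCSc1ccc(O)cc1` reaches the limit of this assay, > 240 h. Compound 3 `Cc1ccc(/N=N/N(C)C(=O)NCCSc2ccc(O)cc2)cc1` likewise reaches a limit, > 240 h. The step that the two limits leave unreadable from compound 2 to compound 3 therefore cannot be read, and the limit of > 240 h in this assay, at which 2 of the 3 values shown sit, is all the two limits tell. Compound 4 `CCOC(=O)c1ccc(/N=N/N(C)C(=O)CCc2ccc(O)cc2)cc1` differs from compound 1 by ethoxycarbonyl in place of methyl on an aromatic carbon. Within the data shown here, no measured step changes this position while leaving the rest of compound 1 untouched, so none bears directly on the change. Compound 4 is therefore expected to lie near its parent value, a 1.5-fold higher number from compound 1 to compound 4 (0.17 log units; within the scatter), at an estimated 150 h with a range from 60 h to 400 h.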

Compound 4, half-life: 130 h
Compound 4: middle estimate off by 1.2-fold (0.06 log units), on the high side, within the range that was stated.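

Among these compounds, at this position, on an aromatic carbon para to a large group, this assay gives the first readable step for a change of group: ethoxycarbonyl in place of methyl gives a 1.3-fold higher number from compound 1 to compound 4 (0.11 log units; within the scatter). The change brings 5 heavy atoms and 2 hydrogen-bond acceptors where methyl had 1 heavy atom and none, yet the step stays within the scatter.

Going by these compounds, whether an amine, a carboxylic acid or a longer chain at this position would also stay within the scatter remains open. The step between compound 2 and compound 3 still cannot be read: the limit of > 240 h in this assay, at which 2 of the 4 values shown sit.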